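The compounds below may be only part of what the source reports. "The series", "measured", "known", "first", "only" and "open" are said of these compounds alone.

Compounds measured so far:
compound 1 `Nc1cc(N)c2nc(-c3ccccc3)c(Oc3ccc(Cl)c(Cl)c3)nc2c1` — 11500 nM
compound 2 `CCOC(=O)[C@H](CCC(=O)O)NC(=O)c1ccc(CNc2nc3cc(N)cc(N)c3nc2-c2ccccc2)cc1` — < 100000 nM
compound 3 `CCOC(=O)[C@H](CCC(=O)O)NC(=O)c1ccc(Sc2nc3cc(N)cc(N)c3nc2-c2ccccc2)cc1` — 50100 nM

In a functional assay on SN12C cells (Homo sapiens) for inhibition, read by sulforhodamine B assay, with a stated time of 48 h (a lower number here means a stronger inhibitor of growth, a higher number a weaker inhibitor of growth), compound 1 holds the lowest of the two numbers; compound 3 sits above it by a gap beyond the scatter. For compound 2 this assay reports only a limit, not a number (the limit of < 100000 nM in this assay, at which 1 of the 3 values shown sits).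

Compound 4 `COc1ccc(Sc2nc3cc(N)cc(N)c3nc2-c2ccccc2)cc1` has not yet been measured. It differs from compound 1 in one place, ((4-methoxyphenyl)sulfanyl in place of 3,4-dichlorophenoxy on an aromatic carbon). Within the data shown here, no measured pair reproduces this change; compound 3 also carries an arylsulfanyl group on the shared core and gives a higher number than compound 1. A weakening step from compound 1 is therefore expected, a 1.9-fold higher number from compound 1 to compound 4 (0.28 log units; within the scatter), of moderate size. Compound 4 is estimated at 22000 nM in this assay, within a range from 6000 nM to 80000 nM.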

Compound 4, concentration for 50% growth inhibition: 6030 nM
Beside the measured number, compound 4's estimate is 3.6-fold (0.56 log units) above it; the measured number falls inside the stated range.
By their numbers in this assay, from the lowest: compounds 4 and 1 (each within the scatter of the next); then compound 3.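

In this assay, (4-methoxyphenyl)sulfanyl and 3,4-dichlorophenoxy are interchangeable on this aromatic carbon next to the ring nitrogen, with a 1.9-fold lower number from compound 1 to compound 4 (0.28 log units; within the scatter). Compound 4 shares its arylsulfanyl group with compound 3, whose number is 50100 nM, so that group alone does not fix the number in this series. No measurement shown gives a cause for this step.

From the compounds shown here alone, the step swaps the linking atom and the ring substituents together, so their separate contributions stay open. Also open, going by these compounds, is what a morpholine at this position would give.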